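A few compounds are considered here, and "the series" means these few. Any claim that something is new, unique, unknown or untested is made for them only; others in the source may bear on it.

Measured compounds:
Compound 1 `CC(C(=O)NCc1ccc(C(F)(F)F)nc1NCc1ccccc1)c1ccc(NS(C)(=O)=O)c(F)c1`, which in a functional assay on CHO-K1 cells for antagonist activity at transient receptor potential cation channel subfamily V member 1 (Homo sapiens), read by FLIPR (on this read-out higher numbers stand for weaker inhibition and lower numbers for stronger inhibition), gives 15.8 nM.
Compound 2 `C[C@H](C(=O)NCc1ccc(C(F)(F)F)nc1N1CC[C@@H](OCc2ccccc2)C1)c1ccc(NS(C)(=O)=O)c(F)c1`, which in this assay gives 1.4 nM.
Compound 3 `C[C@H](C(=O)NCc1ccc(C(F)(F)F)nc1N1CC[C@@H](N(C)C)C1)c1ccc(NS(C)(=O)=O)c(F)c1`, which in this assay gives 101 nM.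

Compound 1 holds the second highest of the three numbers in this assay. Compound 3 is nearest to it, its number being higher, and compound 2 is furthest, with a lower number; both of those gaps lie beyond the scatter, so compound 2 is the strongest inhibitor of the three.

Compound 4 `CC(C(=O)NCc1ccc(C(F)(F)F)nc1N1CCC(=O)CC1)c1ccc(NS(C)(=O)=O)c(F)c1` is not yet measured. It differs from compound 1 in one place (4-oxopiperidin-1-yl in place of benzylamino on an aromatic carbon). The group that leaves carries the six-membered aromatic ring of carbon only; the group that enters is a six-membered non-aromatic ring with one hetero atom and a carbonyl.

Among the measured compounds shown here, no measured step removes benzylamino from an aromatic carbon. The step that comes closest is a 72-fold higher number from compound 2 to compound 3 (1.86 log units; beyond the scatter), where the benzyl-bearing group is lost from a saturated ring carbon and a much higher number follows. By that analogy the loss of the benzyl in compound 4 is expected to raise the number beyond the scatter, so a 7.6-fold higher number from compound 1 to compound 4 (0.88 log units; beyond the scatter) is estimated. For compound 4 in this assay the estimate is 120 nM, within the range 30 nM to 500 nM.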

Compound 4, inhibition constant: 91 nM
The estimate for compound 4 lay 1.3-fold (0.12 log units) above the measured number; the range from low to high includes it.
By their numbers in this assay, from the lowest: compound 2; then compound 1; then compounds 4 and 3 (each within the scatter of the next).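

In this assay, 4-oxopiperidin-1-yl in place of benzylamino on the aromatic carbon next to the ring nitrogen brings a 5.8-fold higher number from compound 1 to compound 4 (0.76 log units; beyond the scatter), the only step shown that changes this position itself. The earlier step, by contrast, concerned a group on a saturated ring carbon and left the attachment to the aromatic carbon unchanged. This new step shows that the exchange at the aromatic carbon, which takes away the six-membered aromatic ring of carbon only and the hydrogen-bond donor and brings in a non-aromatic ring with a carbonyl, moves the number beyond the scatter, though nothing measured here accounts for the rise or divides it among these differences.

The compounds shown leave open how much of the step goes with the loss of the aromatic ring, how much with the loss of the donor and how much with the carbonyl. As far as these compounds go, a plain piperidin-1-yl, a 4-hydroxypiperidin-1-yl or a 4-benzyloxypiperidin-1-yl at the same aromatic carbon would each separate part of this, and how any of them would stand in this assay remains unknown.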